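This account rests on a few compounds, and the source may have more. Where it says the series, first, only, none or still open, it means among the compounds named here.

Of the compounds shown here, three with a shared core have been tested in a functional assay on A549 cells (Homo sapiens) for antiproliferative activity, read by MTT assay, with a stated time of 72 h; on this read-out lower numbers stand for stronger inhibition and higher numbers for weaker inhibition. Compound 1 `NC1=NC2(CCSCC2)N(OCCCOc2cccc(Cl)c2)C(N)=N1` gives 60 nM in this assay. Compound 2 `NC1=NC2(CCOCC2)N(OCCCOc2cc(Cl)c(Cl)cc2Cl)C(N)=N1` gives 680 nM. Compound 3 `NC1=NC2(CCSCC2)N(OCCCOc2ccc(Cl)cc2)C(N)=N1` gives 580 nM, which is the second highest of the three numbers; the value of compound 2 sits within the scatter of it, while the step of a 9.7-fold higher number from compound 1 to compound 3 (0.99 log units; beyond the scatter) is beyond the scatter, so compound 1 inhibits growth more strongly than compound 3.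

Compound 4 `CC(C)(C)c1ccc(OCCCON2C(N)=NC(N)=NC23CCSCC3)cc1` differs from compound 3 in one place: tert-butyl in place of chloro on an aromatic carbon.

Among the compounds with values here, no measured step swaps chloro for tert-butyl anywhere. Within the data shown here, the only step that touches the same ring, a 9.7-fold higher number from compound 1 to compound 3 (0.99 log units; beyond the scatter), moves the chloro from one position to another and says nothing about replacing it with a larger carbon group. Among the measured compounds shown here, with no directly comparable step, the expectation for this assay rests on the value of compound 3 alone, and the most defensible guess is a step of a 1.2-fold lower number from compound 3 to compound 4 (0.06 log units; within the scatter) that stays within the usual scatter, with the range widened to allow for either direction. Compound 4 is therefore estimated at 500 nM, with a range from 150 nM to 1700 nM.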

Compound 4, half-maximal inhibitory concentration: 1 nM
For compound 4 the middle estimate is 500-fold (2.70 log units) above the measured one; the measured number lies below the stated range.
By their numbers in this assay, from the lowest: compound 4; then compound 1; then compounds 3 and 2 (each within the scatter of the next).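

Within the data shown here, replacing the chloro with tert-butyl on this aromatic carbon gives a 580-fold lower number from compound 3 to compound 4 (2.76 log units; beyond the scatter) in this assay, the largest step so far. Among these compounds, until now, the only step on this ring was a 9.7-fold higher number from compound 1 to compound 3 (0.99 log units; beyond the scatter), which showed that the location of the chloro matters; the new step shows that the identity of the group at this carbon matters as well, and that here the larger group, with 4 heavy atoms against 1, goes with far stronger inhibition of growth. The data shown offer no measurement that explains why this swap has so great an effect.

From the compounds shown here alone, with only chloro and tert-butyl to compare at this carbon, it remains open whether the gain extends to other carbon groups, such as methyl or isopropyl, or to a group such as methoxy or trifluoromethyl. Going by these compounds, it is also open whether tert-butyl would bring a similar gain with the oxygen-containing ring of compound 2 in place of the sulfur-containing ring of compound 3, or at the position the chloro occupies in compound 1.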